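Swapping the urea aryl on a triazolyl pyridine ether

The source may report more compounds than this note shows. Statements on the series, on what has been measured and on what is new or still open speak of the compounds shown alone.

In an ADME assay on WI-38 cells (Homo sapiens) for cytotoxicity, read by MTT assay, with a stated time of 72 h (on this read-out lower numbers stand for stronger inhibition and higher numbers for weaker inhibition), compound 1 `Cn1ncnc1-c1cc(Oc2ccc(NC(=O)Nc3cccc(C(F)(F)F)c3)cc2F)ccn1` gives 22400 nM, and compound 2 `CN(C)CCn1cnnc1-c1cc(Oc2ccc(NC(=O)Nc3cccc(C(F)(F)F)c3)cc2F)ccn1` gives 11200 nM. The step of a 2.0-fold lower number from compound 1 to compound 2 (0.30 log units; within the scatter) is the only measured one, and it alters the triazole side of the shared core. Compound 2 and compound 1 thus lie within the scatter of each other. Compound 3 `CN(C)CCn1cnnc1-c1cc(Oc2ccc(NC(=O)Nc3ccc(F)c(F)c3)cc2F)ccn1` carries 3,4-difluorophenyl in place of 3-(trifluoromethyl)phenyl on an amide-type nitrogen. Going by the values given here, no measured step touches this urea aryl, so the data give no guide to its effect. Compound 3 is therefore expected to shift by a 1.0-fold lower number from compound 2 to compound 3 (0.01 log units; within the scatter), nothing beyond the scatter. Compound 3 is estimated at 11000 nM, with a range from 4000 nM to 30000 nM.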

Compound 3, half-maximal inhibitory concentration: > 50000 nM
Compound 3 gave a limit, no number (the forecaster's own chance of this, stated with the estimate: 10%); at least 4.5-fold (0.65 log units) between middle value and limit.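

The urea aryl on the amide-type nitrogen proves to matter in this assay: 3,4-difluorophenyl in place of 3-(trifluoromethyl)phenyl gives an at least 4.4-fold higher number from compound 2 to compound 3 (0.64 log units; beyond the scatter), whereas the earlier triazole change stayed within the scatter. Compound 3 gives a limit of the assay and not a number: the limit of > 50000 nM in this assay, at which 1 of the 3 values shown sits. On these data alone, this position can therefore carry a change beyond the scatter, although the full size of this step remains unknown.

As far as these compounds go, it remains open whether the same swap would act alike on compound 1. Also open, from the compounds shown here alone, is what a chlorine, a methoxy group or a single fluorine on this phenyl ring would give.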